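A Hydroxy Group Added to the Weakest of Three

This account rests on a few compounds, and the source may have more. Where it says the series, first, only, none or still open, it means among the compounds named here.

Going by the values given here, in a functional assay on HT-29 cells (Homo sapiens) for antiproliferative activity, with a stated time of 4 h (on this read-out higher numbers stand for weaker inhibition and lower numbers for stronger inhibition), three related compounds have numbers so far. Compound 1 `O=C1NC(=O)c2c1c1c(c3[nH]c4ccccc4c23)C(=O)CCC1` gives 15500 nM and compound 3 `O=c1ccc(=O)c2c1c1[nH]c3ccccc3c1c1c(=O)[nH]c(=O)c21` gives 17400 nM with these two values lying within the usual scatter of each other. Compound 2 `O=C1NC(=O)c2c1c1c(O)cccc1c1[nH]c3ccccc3c21` gives 46400 nM as the highest of the three numbers, which makes it the weakest inhibitor here, and its gaps to both others lie beyond the scatter.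

Compound 4 `O=C1NC(=O)c2c1c1c(O)ccc(O)c1c1[nH]c3ccccc3c21` has not yet been measured. It is compound 2 with one change, hydroxy in place of hydrogen on an aromatic carbon and the new group stands para to the hydroxy group already present.

Among the compounds with values here, no measured pair differs by this single change, so the data give no direct size for the step in this assay. There is only a weak hint. Compound 2 sits at the top of the range, while compound 1 at 15500 nM and compound 3 at 17400 nM show that lower numbers occur among these relatives. A modest move to a lower number, meaning somewhat stronger inhibition, is therefore expected. The expected change is a 2.1-fold lower number from compound 2 to compound 4 (0.32 log units; beyond the scatter) and it is estimated to fall close to the edge of the scatter. For compound 4 the estimated value is 22000 nM within an expected range of 8000 nM to 60000 nM on the same read-out.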

Compound 4, half-maximal inhibitory concentration: 5600 nM
Compound 4: middle estimate off by 3.9-fold (0.59 log units), on the high side; the whole stated range lies above it.
By their numbers in this assay, from the lowest: compound 4; then compounds 1 and 3 (each within the scatter of the next); then compound 2.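

In this assay this position proves responsive: replacing hydrogen with a hydroxy group on this aromatic carbon, para to the hydroxy group already present, gives an 8.3-fold lower number from compound 2 to compound 4 (0.92 log units; beyond the scatter) and so stronger inhibition. Going by these compounds alone, this is the first direct size for a single change in this small series, since no earlier pair differed in only one place. It also shows that the ring already carrying one hydroxy group can take a second at this position and gain activity rather than lose it. No measurement shown here accounts for the size of this step, so it stands as an observation without an explanation.

From the compounds shown here alone, whether the hydroxy group itself matters at this position stays open, as a single replacement cannot show how a methoxy group, an amine or a carboxylic acid placed there would compare. Going by these compounds, it also remains unknown whether the new hydroxy group would give a similar step without the existing hydroxy group, as this one step shows the change only with that group in place.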